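The source may hold more compounds than are shown below. What is called first, only, known or untested is meant among the compounds shown, and "the series" means these compounds.

Of the compounds shown here, three built on one shared core have been measured in a functional assay on L1210 cells (Mus musculus) for cytotoxicity; on this read-out higher numbers stand for weaker inhibition and lower numbers for stronger inhibition. Compound 1 `O=C(/C=C/C(=O)N1C/C(=C\c2ccc([N+](=O)[O-])cc2)C(=O)/C(=C/c2ccc([N+](=O)[O-])cc2)C1)Nc1ccc(Cl)c(Cl)c1` gives 1700 nM in this assay. Compound 2 `CC(=O)c1ccc(NC(=O)/C=C/C(=O)N2C/C(=C\c3ccc([N+](=O)[O-])cc3)C(=O)/C(=C/c3ccc([N+](=O)[O-])cc3)C2)cc1` gives 1400 nM, and compound 3 `Cc1ccc(NC(=O)/C=C/C(=O)N2C/C(=C\c3ccc([N+](=O)[O-])cc3)C(=O)/C(=C/c3ccc([N+](=O)[O-])cc3)C2)cc1C` gives 4900 nM. Compound 3 thus carries the highest number of the three: the step of a 2.9-fold higher number from compound 1 to compound 3 (0.46 log units; beyond the scatter) and the step of a 3.5-fold higher number from compound 2 to compound 3 (0.54 log units; beyond the scatter) both lie beyond the scatter, whereas the step of a 1.2-fold lower number from compound 1 to compound 2 (0.08 log units; within the scatter) does not.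

Compound 4 `Cc1cccc(C)c1NC(=O)/C=C/C(=O)N1C/C(=C\c2ccc([N+](=O)[O-])cc2)C(=O)/C(=C/c2ccc([N+](=O)[O-])cc2)C1` has not yet been measured. It differs from compound 3 by 2,6-dimethylphenyl in place of 3,4-dimethylphenyl on an amide-type nitrogen; the two dimethylphenyl groups hold the same atoms, joined differently. For the measured compounds named here, none of the measured steps moves methyl groups around a ring in this way. The steps from compound 1 and from compound 2 to compound 3 each swap one substituted phenyl for a phenyl with other substituents, and both were modest in size. Going by the values given here, no measured step speaks directly to the present change, so no step beyond the scatter is expected in this assay in either direction, though the range left open is wide. Compound 4 is therefore estimated at 4900 nM, with a range from 1800 nM to 13000 nM, the step of no change at the digits printed from compound 3 to compound 4 (within the scatter) being expected to stay within the scatter.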

Compound 4, half-maximal inhibitory concentration: 690 nM
Estimate against measurement, compound 4: 7.1-fold (0.85 log units) above; measured number outside the range, below it.
By their numbers in this assay, from the lowest: compound 4; then compounds 2 and 1 (each within the scatter of the next); then compound 3.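

Moving the two methyl groups around the ring, with no atom gained or lost, shifts the result in this assay by a 7.1-fold lower number from compound 3 to compound 4 (0.85 log units; beyond the scatter), the largest step among these compounds. At this place on the amide-type nitrogen, then, the arrangement of the substituents counts and not only their identity, something the earlier swaps could not show because each of them also changed the atoms. The 2,6-dimethylphenyl group also gives a 2.0-fold lower number from compound 2 to compound 4 (0.31 log units; beyond the scatter) and a 2.5-fold lower number from compound 1 to compound 4 (0.39 log units; beyond the scatter), which makes compound 4 the most potent of the four, and nothing measured here explains why this rearrangement has such an effect.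

The compounds shown do not reveal whether both methyl groups of the 2,6-dimethylphenyl group are needed, since no plain phenyl or phenyl with a single methyl group stands among them for comparison. Nor do they tell whether the gain survives when the methyl groups give way to ethyl groups, or to a ring carrying an amine or a carboxylic acid.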